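Imidazole for piperidine on the propyl chain of compound 1

The compounds below may be only part of what the source reports. "The series", "measured", "known", "first", "only" and "open" are said of these compounds alone.

Measured compounds:
compound 1, `Cn1cc(C2=C(c3nn(CCCN4CCCCC4)c4ncccc34)C(=O)N(c3ccccc3)C2=O)c2ccccc21`, 5600 nM
compound 2, `Cn1cc(C2=C(c3nn(CCCN4CCCCC4)c4ncccc34)C(=O)N(c3cccc4ccccc34)C2=O)c2ccccc21`, 13400 nM

In a functional assay on KB cells (Homo sapiens) for antiproliferative activity, read by MTT assay, with a stated time of 48 h (a higher number here means a weaker inhibitor, a lower number a stronger inhibitor), compound 1 gives the lowest of the two numbers; compound 2 stands a 2.4-fold higher number from compound 1 to compound 2 (0.38 log units; beyond the scatter) away. Compound 3, `Cn1cc(C2=C(c3nn(CCCn4ccnc4)c4ncccc34)C(=O)N(c3ccccc3)C2=O)c2ccccc21`, is not yet measured. It differs from compound 1 by 1H-imidazol-1-yl in place of piperidin-1-yl on a saturated chain carbon, three bonds along the chain from an aromatic nitrogen. Among the measured compounds shown here, the one measured step concerns the amide-type nitrogen in a ring, a different place, so no step bears on this change and its direction is open. The step from compound 1 to compound 3 is therefore expected to be a 1.1-fold higher number from compound 1 to compound 3 (0.03 log units; within the scatter). Compound 3 is estimated at 6000 nM, within 1500 nM to 25000 nM.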

Compound 3, half-maximal inhibitory concentration: 6800 nM
The estimate for compound 3 lay 1.1-fold (0.05 log units) below the measured number, within the range that was stated.
By their numbers in this assay, from the lowest: compounds 1, 3 and 2 (each within the scatter of the next, the first and the last beyond it).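

In this assay the replacement of 3-(piperidin-1-yl)propyl by 3-(1H-imidazol-1-yl)propyl gives a 1.2-fold higher number from compound 1 to compound 3 (0.08 log units; within the scatter) here, so the two end groups are not told apart in this read-out. Among the compounds shown here, this is the first reading at this position, as the earlier step concerned only the amide-type nitrogen in a ring. Nothing available explains the result.

Still open, from the compounds shown here alone, is whether a morpholine or a dimethylamino group on the same chain would separate from compound 1. Going by these compounds, a longer chain carrying the imidazole, or a shorter one, also remains untested here.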